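A few compounds are considered here, and "the series" means these few. Any claim that something is new, unique, unknown or untested is made for them only; others in the source may bear on it.

Measured compounds:
Compound 1 `COc1cccc(/C=C/C(=O)c2ccc(OC)c3c2OC(C)(C)C=C3)c1` — > 10000 nM
Compound 2 `COc1ccc(C(=O)/C=C/c2ccc(Br)cc2)c2c1C=CC(C)(C)O2` — > 10000 nM

In a functional assay on HT-29 cells (Homo sapiens) for antiproliferative activity, read by MTT assay, with a stated time of 24 h (a higher number here means a weaker inhibitor, a lower number a stronger inhibitor), compound 1 gives > 10000 nM, which is a limit of the assay and not a number. In this assay compound 2 likewise gives > 10000 nM, again a limit rather than a measured number. Among the compounds with values here, the single step between the two, a step that the two limits leave unreadable from compound 1 to compound 2, is therefore unreadable, because of the limit of > 10000 nM in this assay, at which 2 of the 2 values shown sit. Compound 2 thus stands at the limit, and nothing in the numbers sets it apart from compound 1.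

Compound 3 `COc1ccc(C(=O)/C=C/c2ccc(-n3ccnc3)cc2)c2c1C=CC(C)(C)O2` differs from compound 2 by 1H-imidazol-1-yl in place of bromo on an aromatic carbon. Within the data shown here, no measured step bears on this exchange: the one step in hand concerns a different change and is itself without a readable size. Among the measured compounds shown here, with both measured compounds sitting at the limit, the expected step that the limit leaves unreadable from compound 2 to compound 3 rests on no precedent, and a value near the limit is expected for compound 3, with a real chance that only a limit is again reported. Compound 3 is estimated at 12000 nM in this assay, with a range from 2000 nM to 50000 nM.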

Compound 3, half-maximal inhibitory concentration: > 6600 nM
Compound 3 was reported as a limit; the forecaster's own chance of this, stated with the estimate: 60%; the middle value lies beyond the limit too.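

In this assay compound 3 gives > 6600 nM, a limit of the assay and not a number. Compound 2 and compound 3 both stand at limits, and the step between them cannot be read. The compounds shown leave open whether 1H-imidazol-1-yl in place of bromo alters antiproliferative activity at all, and in which direction.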